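Swapping Propyl for Fluoro on a Weakly Cytotoxic Series

This account rests on a few compounds, and the source may have more. Where it says the series, first, only, none or still open, it means among the compounds named here.

Measured so far:
Compound 1, `CCCc1ccc(-c2ccc3ncc(C(=O)OCC)cc3c2)cc1` — in a functional assay on RD cells (Homo sapiens) for inhibition, read by luminescence and ATP content, with a stated time of 72 h (a higher number here means that more compound is tolerated, a lower number that less compound is tolerated), compound 1 gives > 7400 nM, which is a limit of the assay and not a number.
Compound 2, `CCCc1ccc(-c2ccc3ncc(-c4noc(CC)n4)cc3c2)cc1` — in this assay compound 2 gives > 7400 nM, likewise a limit of the assay.

For the measured compounds named here, the one measured step, a step that the two limits leave unreadable from compound 1 to compound 2, therefore cannot be read. Both values sit at the limit of > 7400 nM in this assay, at which 2 of the 2 values shown sit. Compound 2 thus stands at the top of what this assay can report, with no number of its own.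

Compound 3, `CCc1nc(-c2cnc3ccc(-c4ccc(F)cc4)cc3c2)no1`, differs from compound 2 by fluoro in place of propyl on an aromatic carbon. Going by the values given here, no measured pair shares this change, and the single step available gives no size in either direction. There is nothing that points to compound 3 becoming more toxic to these cells, so the expectation is no step beyond the scatter, and the estimated step that the limit leaves unreadable from compound 2 to compound 3 reflects that. Compound 3 is expected to give about 9000 nM in this assay, within a range from 4000 nM to 20000 nM, most likely returned again as a limit.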

Compound 3, half-maximal cytotoxic concentration: > 7400 nM
Compound 3: only a limit was reported (the forecaster's own chance of this, stated with the estimate: 80%); the middle value does not contradict the limit.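

Compound 3, like compound 2, is reported only as a limit in this assay and not as a number, so the step between them cannot be read: the limit of > 7400 nM in this assay, at which 3 of the 3 values shown sit. The compounds shown leave open how much of each compound the cells actually tolerate, and whether fluoro in place of propyl changes that at all.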